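The source may hold more compounds than are shown below. What is called first, only, known or untested is meant among the compounds shown, and "the series" means these compounds.

Compound 1 `Cc1c(O)c(=O)ccn1CCCc1cc(C(C)(C)C)c(O)c(C(C)(C)C)c1` is known in an ADME assay for solubility (on this read-out lower numbers stand for lower solubility and higher numbers for higher solubility), only by a limit: compound 1 gives < 100 ug/mL, which is a bound of the assay and not a number. Compound 2 `CNCC(=O)Oc1c(C)c(C)c2c(c1C)CC(CCn1ccc(=O)c(O)c1C)O2` also sits at a limit in this assay, giving > 20000 ug/mL. Compound 3 `Cc1c(OC(=O)CCN)c(=O)ccn1CCCc1cc(C(C)(C)C)c(O)c(C(C)(C)C)c1` differs from compound 1 by (2-aminoethyl)carbonyl in place of hydrogen on an oxygen on an aromatic ring. Going by the values given here, no step between measured compounds is at hand, so the expectation rests on the change alone; a large rise in solubility is expected, an at least 20-fold higher number from compound 1 to compound 3 (1.30 log units; beyond the scatter). Compound 3 is thus estimated at 2000 ug/mL, with a range from 300 ug/mL to 15000 ug/mL.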

Compound 3, solubility: > 20000 ug/mL
Compound 3 ended at the assay's limit; the forecaster's own chance of this, stated with the estimate: 30%; middle value at least 10-fold (1.00 log units) from the limit.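

Going by these compounds alone, on the oxygen on an aromatic ring, (2-aminoethyl)carbonyl in place of hydrogen gives the first step that can be read in this assay: an at least 200-fold higher number from compound 1 to compound 3 (2.30 log units; beyond the scatter). This step runs between two limits of the assay and not between two numbers, so its printed size is only a lower bound. The earlier compounds shown here offered no such comparison, since compound 2 differs from compound 1 in more than one place.

As far as these compounds go, the actual solubility of compound 3 remains open. So does whether a longer chain between the carbonyl and the amine, or a carboxylic acid in place of the amine, would reach the same limit.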